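A Phenethyl Chain in Place of 4-Methoxyphenyl

The source may report more compounds than this note shows. Statements on the series, on what has been measured and on what is new or still open speak of the compounds shown alone.

Compound 3 `COc1ccc(-c2ccc3c(NCCCNCc4cccc(OC)c4O)ccnc3c2)cc1` gives 237 10^-6 cm/s in an ADME assay for permeability, using PAMPA, with a stated time of 30 min, at pH 7.4; a higher number here means that the compound crosses the layer faster, a lower number that the compound crosses the layer more slowly. Compound 1 `COc1cccc(CNCCCNc2ccnc3cc(-c4ccc(C(F)(F)F)cc4)ccc23)c1O` gives 237 10^-6 cm/s and compound 2 `COc1cccc(Oc2ccc3c(NCCCNCc4cccc(OC)c4O)ccnc3c2)c1` gives 317 10^-6 cm/s in this assay; compound 3 is level with compound 1, and the remaining gap is a 1.3-fold lower number from compound 2 to compound 3 (0.13 log units; within the scatter). Compound 4 `COc1cccc(CNCCCNc2ccnc3cc(CCc4ccccc4)ccc23)c1O` differs from compound 3 by phenethyl in place of 4-methoxyphenyl on an aromatic carbon. All three measured steps vary the group on this aromatic carbon: no change at the digits printed from compound 1 to compound 3 (within the scatter), a 1.3-fold higher number from compound 1 to compound 2 (0.13 log units; within the scatter) and a 1.3-fold lower number from compound 2 to compound 3 (0.13 log units; within the scatter). Among the measured compounds shown here, none of them exchanges an aromatic group for a chain, so no step bears directly on the change, yet every variation made there has stayed within the scatter. Compound 4 is therefore expected to give 240 10^-6 cm/s, between 140 10^-6 cm/s and 400 10^-6 cm/s. For compound 4 this estimate means a step of a 1.0-fold higher number from compound 3 to compound 4 (0.01 log units; within the scatter), none beyond the scatter.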

Compound 4, apparent permeability: 23 10^-6 cm/s
Compound 4: the middle estimate sits 10-fold (1.02 log units) above what was measured, outside the stated range (below it).
By their numbers in this assay, from the lowest: compound 4; then compounds 1, 3 and 2 (each within the scatter of the next).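

In this assay this aromatic carbon turns out not to be indifferent to what it carries: phenethyl brings a 10-fold lower number from compound 3 to compound 4 (1.01 log units; beyond the scatter) and a 10-fold lower number from compound 1 to compound 4 (1.01 log units; beyond the scatter) and a 14-fold lower number from compound 2 to compound 4 (1.14 log units; beyond the scatter) while 4-methoxyphenyl, 4-(trifluoromethyl)phenyl and 3-methoxyphenoxy stay within the scatter of one another. Phenethyl and 4-methoxyphenyl have the same count of heavy atoms and each holds one six-membered aromatic ring, so those counts do not separate compound 4 from compound 3. Nothing available here accounts for the step.

The compounds shown leave open whether benzyl, phenylpropyl or 4-methoxyphenethyl would give a number like that of compound 4 or like those of the other three. They also leave open whether an amine on the chain would change the result.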